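Shortening the Alkoxy Chain on a Purine-like Core

This account rests on a few compounds, and the source may have more. Where it says the series, first, only, none or still open, it means among the compounds named here.

Measured compounds:
compound 1, `CCCCc1nc(N)c2nc(O)n(Cc3ccccc3)c2n1`, gives 0.03 uM in a functional assay (spleen, spleen) for activation, with Mus musculus as the target; a lower number here means that less compound is needed, a higher number that more compound is needed for the effect
compound 2, `CCc1nc(N)c2nc(O)n(Cc3ccccc3)c2n1`, gives 1 uM in this assay
compound 3, `CCCOc1nc(N)c2nc(O)n(Cc3ccccc3)c2n1`, gives 0.01 uM in this assay

Compound 3 needs the least compound of the three; the step of a 3.0-fold lower number from compound 1 to compound 3 (0.48 log units; beyond the scatter) comes from propoxy in place of butyl on an aromatic carbon, and the step of a 100-fold lower number from compound 2 to compound 3 (2.00 log units; beyond the scatter) is larger still. The change from compound 1 to compound 2 is hydrogen in place of ethyl on a saturated chain carbon, two bonds along the chain from an aromatic carbon, and it costs a 33-fold higher number from compound 1 to compound 2 (1.52 log units; beyond the scatter).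

Compound 4, `COc1nc(N)c2nc(O)n(Cc3ccccc3)c2n1`, has not yet been measured. It differs from compound 3 by hydrogen in place of ethyl on a saturated chain carbon bound to an oxygen on an aromatic ring. This is the same kind of change as that from compound 1 to compound 2, but not the same: there the carbon sat two bonds along the chain from an aromatic carbon, here it is bound to an oxygen on an aromatic ring. The cores also differ, as described by the change from compound 1 to compound 3.

Since cutting two carbons off the chain cost a 33-fold higher number from compound 1 to compound 2 (1.52 log units; beyond the scatter), a comparable loss is expected for a 30-fold higher number from compound 3 to compound 4 (1.48 log units; beyond the scatter). Compound 4 is thus estimated at about 0.3 uM, between 0.1 uM and 1 uM.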

Compound 4, minimum effective concentration: 0.1 uM
Estimate against measurement, compound 4: 3.0-fold (0.48 log units) above, and the stated range covers the measured number.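

In this assay, taking ethyl off the chain gives a 10-fold higher number from compound 3 to compound 4 (1.00 log units; beyond the scatter), so the change moves the number in the same direction on the propoxy compound as on the butyl compound, but its size does not carry over unchanged: the same change on two cores in this assay, a 33-fold higher number (1.52 log units; beyond the scatter) from compound 1 to compound 2 and a 10-fold higher number (1.00 log units; beyond the scatter) from compound 3 to compound 4, 3.3-fold (0.52 log units) apart, beyond the scatter of two such steps. On an aromatic carbon, methoxy still compares well with ethyl, with a 10-fold lower number from compound 2 to compound 4 (1.00 log units; beyond the scatter), whereas replacing butyl with methoxy gives a 3.3-fold higher number from compound 1 to compound 4 (0.52 log units; beyond the scatter), so the shorter chain with an oxygen does not match the longer all-carbon chain. Among these compounds, with only two such pairs, this shows that the direction held here, but it gives no general rule for other cores and does not explain why the two steps differ in size.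

On these data alone, it remains open whether propoxy is the best of the alkoxy chains or whether a longer chain, such as butoxy, would lower the number further. As far as these compounds go, how an amine on the same aromatic carbon would compare is also open.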